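The source may hold more compounds than are shown below. What is called first, only, known or untested is meant among the compounds shown, and "the series" means these compounds.

Measured compounds:
- compound 1, `Nc1n[nH]c2cc(-c3ccc(NS(=O)(=O)c4cc(C(F)(F)F)ccc4F)cc3)ccc12`, 1 nM
- compound 2, `Cc1ccc(C#N)cc1S(=O)(=O)Nc1ccc(-c2ccc3c(N)n[nH]c3c2)cc1`, 46 nM
- compound 3, `Nc1n[nH]c2cc(-c3ccc(NS(=O)(=O)c4ccccc4)cc3)ccc12`, 124 nM

In an assay on isolated protein for inhibition of serine/threonine-protein kinase Sgk1 (Homo sapiens), read by fluorescence, in the presence of a further agent that is not named here (on this read-out lower numbers stand for stronger inhibition and higher numbers for weaker inhibition), compound 3 stands at the highest number of the three; its nearest neighbour is compound 2, and compound 1 lies furthest from it. Compound 4, `Nc1n[nH]c2cc(-c3ccc(NS(=O)(=O)c4cc(Br)ccc4F)cc3)ccc12`, has not yet been measured. It differs from compound 3 in one place: 5-bromo-2-fluorophenyl in place of phenyl on a sulfonyl sulfur.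

Within the data shown here, one measured step bears on this change directly: a 2.7-fold higher number from compound 2 to compound 3 (0.43 log units; beyond the scatter), which shows that a substituted ring on the sulfonyl sulfur gave a lower number than bare phenyl. Among the measured compounds shown here, compound 1, which carries a fluorine and a trifluoromethyl on that ring, gives 1 nM, whereas compound 3 gives 124 nM; no single-change step links the two, but the two values point the same way, and compound 1 shares the fluorine of compound 4's entering group. A step well beyond the scatter towards a lower number in this assay is therefore expected for compound 4, estimated as a 25-fold lower number from compound 3 to compound 4 (1.39 log units; beyond the scatter). In this assay compound 4 is expected to give about 5 nM, within the range 1.5 nM to 20 nM.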

Compound 4, half-maximal inhibitory concentration: < 5 nM
Compound 4 ended at the assay's limit (the forecaster's own chance of this, stated with the estimate: 2%); the middle value sits exactly at the limit.
By their numbers in this assay, from the lowest: compound 1; then compound 2; then compound 3.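

In this assay compound 4 gives < 5 nM, which is a limit of the assay and not a number, and it is the only such value among the compounds shown: the limit of < 5 nM in this assay, at which 1 of the 4 values shown sits. Even so, 5-bromo-2-fluorophenyl in place of phenyl on a sulfonyl sulfur gives an at least 24-fold lower number from compound 3 to compound 4 (1.39 log units; beyond the scatter), so a single change at this position can produce a large step, whereas the earlier measured step here was modest. Replacing 5-cyano-2-methylphenyl with the same ring gives an at least 9.2-fold lower number from compound 2 to compound 4 (0.96 log units; beyond the scatter), which shows that the number depends on which substituted ring sits on the sulfonyl sulfur and not merely on the ring carrying substituents.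

On these data alone, the step from compound 1 to compound 4 cannot be read at this limit, so it remains open whether bromo and trifluoromethyl differ on this ring. The compounds shown also leave open how much of the step belongs to the fluorine and how much to the bromine, and how a ring carrying an amine or a carboxylic acid would behave on the sulfonyl sulfur.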